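Swapping the amide cap on a shared core

The source may report more compounds than this note shows. Statements on the series, on what has been measured and on what is new or still open speak of the compounds shown alone.

Three compounds share one core and differ only in the group attached to a chain carbon at its edge. Compound 1 `CN1[C@@H]2c3[nH]c4ccccc4c3C[C@H]1[C@H](C#N)N1[C@@H](CN3C(=O)c4ccccc4C3=O)c3[nH]c4ccccc4c3C[C@@H]21` gives, in a functional assay on BGC-823 cells (Homo sapiens) for cytotoxicity, read by MTT assay, with a stated time of 72 h (on this read-out higher numbers stand for weaker inhibition and lower numbers for stronger inhibition), 410 nM. Compound 2 `CN1[C@@H]2c3[nH]c4ccccc4c3C[C@H]1[C@H](C#N)N1[C@@H](CNC(=O)c3ccc(F)cc3)c3[nH]c4ccccc4c3C[C@@H]21` gives 310 nM, and compound 3 `CN1[C@@H]2c3[nH]c4ccccc4c3C[C@H]1[C@H](C#N)N1[C@@H](CNC(=O)c3cc4ccccc4s3)c3[nH]c4ccccc4c3C[C@@H]21` gives 240 nM. Compound 3 has the lowest of the three numbers, yet a 1.3-fold lower number from compound 2 to compound 3 (0.11 log units; within the scatter) and a 1.7-fold lower number from compound 1 to compound 3 (0.23 log units; within the scatter), so all three sit together. Compound 4 `CN1[C@@H]2c3[nH]c4ccccc4c3C[C@H]1[C@H](C#N)N1[C@@H](CNC(=O)/C=C/c3ccccc3)c3[nH]c4ccccc4c3C[C@@H]21` changes the cap once more: 2-phenylethenyl in place of 1-benzothiophen-2-yl on a carbonyl carbon. The two earlier exchanges of this cap, a 1.3-fold lower number from compound 1 to compound 2 (0.12 log units; within the scatter) and a 1.3-fold lower number from compound 2 to compound 3 (0.11 log units; within the scatter), were both small. For compound 4 the step is therefore expected to stay small: a 1.3-fold higher number from compound 3 to compound 4 (0.10 log units; within the scatter). Compound 4 is estimated at 300 nM, within a range of 120 nM to 750 nM.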

Compound 4, half-maximal inhibitory concentration: 4300 nM
The estimate for compound 4 lay 14-fold (1.16 log units) below the measured number; the measured number lies above the stated range.
By their numbers in this assay, from the lowest: compounds 3, 2 and 1 (each within the scatter of the next); then compound 4.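

For the compounds shown here, the cap position is not as forgiving as the earlier compounds suggested: in this assay, 2-phenylethenyl gives an 18-fold higher number from compound 3 to compound 4 (1.25 log units; beyond the scatter), a 14-fold higher number from compound 2 to compound 4 (1.14 log units; beyond the scatter) and a 10-fold higher number from compound 1 to compound 4 (1.02 log units; beyond the scatter). A single six-membered aromatic ring of carbon only cannot alone account for this, since compound 2 carries one too, whereas the double bond outside aromatic rings is found only in compound 4. No measurement here explains the rise. As far as these compounds go, whether that double bond matters remains open; a 2-phenylethyl cap, the same chain with the double bond saturated, would address this.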